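The compounds below may be only part of what the source reports. "The series", "measured", "known", "first", "only" and "open" are said of these compounds alone.

Measured so far in a functional assay on T47D cells (Homo sapiens) for inhibition; a higher number here means a weaker inhibitor, a lower number a stronger inhibitor:
Compound 1 `Oc1ccccc1-c1cc(-c2cccc(C(F)(F)F)c2)cc(-c2ccccc2O)n1` gives > 50000 nM, a limit of this assay.
Compound 2 `Oc1ccccc1-c1cc(-c2ccc(C(F)(F)F)cc2)cc(-c2ccccc2O)n1` gives > 50000 nM, a limit of this assay.
Compound 3 `Oc1ccc(-c2cc(-c3cccc(C(F)(F)F)c3)cc(-c3ccccc3O)n2)cc1` gives > 50000 nM, a limit of this assay.

All three values sit at the same limit (the limit of > 50000 nM in this assay, at which 3 of the 3 values shown sit), so none of these compounds can be ordered against another. Compound 2 differs from compound 1 by 4-(trifluoromethyl)phenyl in place of 3-(trifluoromethyl)phenyl on an aromatic carbon, and the step that the two limits leave unreadable from compound 1 to compound 2. The cores of compound 1 and compound 3 differ by 4-hydroxyphenyl in place of 2-hydroxyphenyl on an aromatic carbon, and the step that the two limits leave unreadable from compound 1 to compound 3. Compound 4 `Oc1ccc(-c2cc(-c3ccc(C(F)(F)F)cc3)cc(-c3ccccc3O)n2)cc1`, not yet measured, differs from compound 3 by 4-(trifluoromethyl)phenyl in place of 3-(trifluoromethyl)phenyl on an aromatic carbon. This is the same kind of change as that from compound 1 to compound 2, not the same: in compound 1 the place is meta to two 2-hydroxyphenyl groups, whereas in compound 3 it is meta to a 2-hydroxyphenyl group and meta to a 4-hydroxyphenyl group. Since every measured value sits at the limit (the limit of > 50000 nM in this assay, at which 3 of the 3 values shown sit), the expected step is a step that the limit leaves unreadable from compound 3 to compound 4, again unreadable. Compound 4 is expected near 80000 nM, between 30000 nM and 300000 nM, and most likely to be reported only as a limit.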

Compound 4, half-maximal inhibitory concentration: > 50000 nM
Compound 4 was reported as a limit; the forecaster's own chance of this, stated with the estimate: 85%; the middle value does not contradict the limit.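

No step can be read between compound 1, compound 2, compound 3 and compound 4, as all four stand at one limit: the limit of > 50000 nM in this assay, at which 4 of the 4 values shown sit. The compounds shown leave open whether 4-(trifluoromethyl)phenyl or 3-(trifluoromethyl)phenyl, or 4-hydroxyphenyl or 2-hydroxyphenyl, makes any difference to inhibition.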